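Swapping the aryl group on a vinyl sulfone anilino core

The source may hold more compounds than are shown below. What is called first, only, known or untested is meant among the compounds shown, and "the series" means these compounds.

Of the compounds shown here, three have been measured in a functional assay on UACC-62 cells (Homo sapiens); a lower number here means a stronger inhibitor of growth, a higher number a weaker inhibitor of growth. Compound 1, `O=S(=O)(/C=C/c1ccc(Cl)cc1Cl)Cc1ccc(Nc2ncnc3ccccc23)cc1`, gives 2000 nM. Compound 2, `O=S(=O)(/C=C/c1ccc(C(F)(F)F)cc1F)Cc1ccc(Nc2ncnc3ccccc23)cc1`, gives 100000 nM. Compound 3, `O=S(=O)(/C=C/c1ccc(Cl)cc1Cl)Cc1ccc(Nc2ncnc3ccc(Br)cc23)cc1`, gives 2000 nM. Compound 3 differs from compound 1 only in its core, and that difference is bromo in place of hydrogen on an aromatic carbon; in this assay it made no change at the digits printed from compound 1 to compound 3 (within the scatter). Compound 1 and compound 2 share a core and differ in the group on the chain: 2-fluoro-4-(trifluoromethyl)phenyl in place of 2,4-dichlorophenyl on a double-bonded chain carbon bound to a double-bonded chain carbon. That change made a 50-fold higher number from compound 1 to compound 2 (1.70 log units; beyond the scatter), the largest step among these three compounds.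

Compound 4, `O=S(=O)(/C=C/c1ccc(C(F)(F)F)cc1F)Cc1ccc(Nc2ncnc3ccc(Br)cc23)cc1`, has not yet been measured. Among the compounds with values here, it carries the core of compound 3 and the chain group of compound 2, so the change from compound 3 to compound 4 is 2-fluoro-4-(trifluoromethyl)phenyl in place of 2,4-dichlorophenyl on a double-bonded chain carbon bound to a double-bonded chain carbon, the same change, at the same place, as the one from compound 1 to compound 2. Within the data shown here, compound 3 stands level with compound 1 in this assay, so the only guide is the step that this change made once already, a 50-fold higher number from compound 1 to compound 2 (1.70 log units; beyond the scatter), and a step of similar size is expected for compound 4: a 50-fold higher number from compound 3 to compound 4 (1.70 log units; beyond the scatter). This rests on one pair alone, and a single pair can mislead. Compound 4 is therefore expected to give about 100000 nM, with a plausible range from 20000 nM to 200000 nM.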

Compound 4, concentration for 50% growth inhibition: 22000 nM
Estimate against measurement, compound 4: 4.5-fold (0.66 log units) above; the range from low to high includes it.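

Replacing 2,4-dichlorophenyl with 2-fluoro-4-(trifluoromethyl)phenyl on the bromo-bearing core again weakened growth inhibition in this assay, with an 11-fold higher number from compound 3 to compound 4 (1.04 log units; beyond the scatter), so the direction of the change carried over from one core to the other, but its size did not: the same change on two cores in this assay, a 50-fold higher number (1.70 log units; beyond the scatter) from compound 1 to compound 2 and an 11-fold higher number (1.04 log units; beyond the scatter) from compound 3 to compound 4, 4.5-fold (0.66 log units) apart, beyond the scatter of two such steps. Seen from the other side of the same four compounds, adding bromo made no difference to the numbers when the chain carried 2,4-dichlorophenyl, yet with 2-fluoro-4-(trifluoromethyl)phenyl on the chain it gave a 4.5-fold lower number from compound 2 to compound 4 (0.66 log units; beyond the scatter), so the result of this change also depended on its partner: the same change on two cores in this assay, no change at the digits printed (within the scatter) from compound 1 to compound 3 and a 4.5-fold lower number (0.66 log units; beyond the scatter) from compound 2 to compound 4, 4.5-fold (0.66 log units) apart, beyond the scatter of two such steps. Together these comparisons show that the two changes do not simply add up across these four compounds, but they do not show why, and a single set of two cores and two chain groups cannot say how far this behaviour extends in the series.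

The compounds shown leave open whether another group in place of the bromo, such as chloro or methoxy, would also soften the loss caused by the chain change. They also leave open whether the same dependence would appear with a different group on the chain, such as an unsubstituted phenyl or a 4-methoxyphenyl.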